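Sulfanyl to sulfonyl step in the series

The source may report more compounds than this note shows. Statements on the series, on what has been measured and on what is new or still open speak of the compounds shown alone.

In a functional assay on DU-145 cells (Homo sapiens) for inhibition, read by trypan blue exclusion, with a stated time of 96 h (a higher number here means a weaker inhibitor of growth, a lower number a stronger inhibitor of growth), compound 1 (`O=C(/C(=C\c1ccccc1OCc1ccccc1)SCc1ccc(F)cc1)c1ccc(Cl)cc1`) gives 1000 nM. Among the measured compounds shown here, compound 2 (`O=C(/C(=C\c1ccccc1OCc1ccccc1)SCc1ccc(F)cc1)c1ccc(Br)cc1`) gives 1000 nM, which leaves compound 1 level with its only measured neighbour. Compound 3 (`COc1ccc(S(=O)(=O)/C(=C/c2ccccc2OCc2ccccc2)C(=O)c2ccc(Cl)cc2)cc1`) is still unmeasured. Its change from compound 1 is (4-methoxyphenyl)sulfonyl in place of (4-fluorobenzyl)sulfanyl on a double-bonded chain carbon bound to a carbonyl carbon and a double-bonded chain carbon, in words (4-methoxyphenyl)sulfonyl in place of (4-fluorobenzyl)sulfanyl on a double-bonded chain carbon bound to a carbonyl carbon and a double-bonded chain carbon. For the measured compounds named here, the only measured step, bromo in place of chloro on an aromatic carbon, reads no change at the digits printed from compound 1 to compound 2 (within the scatter). Going by the values given here, that step lies elsewhere in the molecule, and no measured compound carries a sulfonyl group, so the data give no direct guide to this change. No shift beyond the scatter is therefore expected, with wide uncertainty in either direction, and the estimated step is no change at the digits printed from compound 1 to compound 3 (within the scatter). For compound 3 the expected value is 1000 nM, with an estimated range of 200 nM to 5000 nM.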

Compound 3, concentration for 50% growth inhibition: 1000 nM
The estimate for compound 3 equals the measured number at the digits printed; the measured number falls inside the stated range.
By their numbers in this assay, from the lowest: compounds 1, 2 and 3 (each within the scatter of the next).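

In this assay, the exchange of (4-fluorobenzyl)sulfanyl for (4-methoxyphenyl)sulfonyl gives no change at the digits printed from compound 1 to compound 3 (within the scatter) on a double-bonded chain carbon bound to a carbonyl carbon and a double-bonded chain carbon. The earlier pair spoke only to the halogen on an aromatic carbon, whereas this step shows that the reading holds when the sulfur linkage and the group it carries are replaced together. Nothing measured on these compounds offers an explanation for this outcome.

The step combines two changes, so the sulfonyl group and the 4-methoxyphenyl group remain unseparated; (4-fluorobenzyl)sulfonyl and (4-methoxyphenyl)sulfanyl would divide them. Also open, from the compounds shown here alone, is whether an amine or a carboxylic acid at this same place would keep the reading.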